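The compounds below may be only part of what the source reports. "The series", "measured", "known", "first", "only" and "open" are said of these compounds alone.

- compound 1: `CC(Oc1ccc(Cl)cc1Cl)C(=O)NC(C)c1ccc(F)cc1`, > 100000 nM
- compound 2: `CC(Oc1ccc(Cl)cc1Cl)C(=O)N[C@@H](C)c1ccc(F)cc1`, 32000 nM
- compound 3: `CC(Oc1ccc(Cl)cc1Cl)C(=O)NC(C)(C)c1ccc(F)cc1`, > 100000 nM

In an ADME assay on CHO cells (Cricetulus griseus) for cytotoxicity, read by LDH release (a lower number here means a stronger inhibitor, a higher number a weaker inhibitor), compound 1 gives > 100000 nM. That value is a limit of the assay and not a number. Compound 3 gives > 100000 nM, which is also a limit. Compound 1 thus sits on (the limit of > 100000 nM in this assay, at which 2 of the 3 values shown sit).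

Compound 4, `CCC(NC(=O)C(C)Oc1ccc(Cl)cc1Cl)c1ccc(F)cc1`, has not yet been measured. It departs from compound 1 by one change: methyl in place of hydrogen on a saturated chain carbon, two bonds along the chain from an amide-type nitrogen and an aromatic carbon. Cut one bond further out, this reads methyl to ethyl.

Going by the values given here, two measured steps bear on it, and neither is a direct precedent. The only readable one is an at least 3.1-fold lower number from compound 1 to compound 2 (0.49 log units; beyond the scatter). Among the compounds with values here, this step concerns the fact that one of compounds 1 and 2 is drawn with a defined configuration and the other without, at the place where they differ and adds no atom, so it shows only that compound 2 gives a number, 32000 nM, in this assay. The other step also puts methyl in place of hydrogen, though at a different place, and it is a step that the two limits leave unreadable from compound 1 to compound 3.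

With no readable size for such an addition, no clear step in either direction is expected, and compound 4 will probably remain at or near the limit. The expected step is an at least 1.1-fold lower number from compound 1 to compound 4 (0.04 log units; that floor lies within the scatter). For compound 4 the estimated value is 90000 nM, with an expected range from 30000 nM to 200000 nM.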

Compound 4, half-maximal inhibitory concentration: > 100000 nM
Compound 4 gave a limit, no number; the forecaster's own chance of this, stated with the estimate: 60%; middle value at least 1.1-fold (0.04 log units) away from the limit.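

In this assay compound 4 gives > 100000 nM, which is a limit of the assay and not a number. Compound 1 gives > 100000 nM, also a limit, so the step between these two compounds cannot be read. The compounds shown leave open whether going from methyl to ethyl at this place changes the number in this assay at all.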